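The source may hold more compounds than are shown below. What is called first, only, known or untested is meant among the compounds shown, and "the series" means these compounds.

Of the compounds shown here, three from the same series have been measured in a functional assay on HeLa cells (Homo sapiens) for cytotoxicity, read by WST assay, with a stated time of 48 h; a lower number here means a stronger inhibitor, a higher number a weaker inhibitor. Compound 1 `COC[C@@H](C(C)C)C(c1ccc(O)c(OC)c1)c1ccc(O)c(OC)c1` gives 69000 nM. Compound 2 `COC[C@@H](C)[C@H](C)C(c1ccc(O)c(OC)c1)c1ccc(O)c(OC)c1` gives 58000 nM, and compound 3 `COc1ccc(C(c2ccc(OC)c(OC)c2)[C@H](C)[C@@H](C)CO)cc1OC` gives 67000 nM. Compound 2 holds the lowest of the three numbers, but its gaps to compound 3 and to compound 1 are both within the scatter of the measurement, so no order among them can be claimed. Going by the values given here, the only single-site step recorded is the one a 1.2-fold lower number from compound 1 to compound 2 (0.08 log units; within the scatter), which touches the same saturated chain carbon bound to two aromatic carbons that is altered next.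

Compound 4 `COc1cc(C(c2ccc(O)c(OC)c2)[C@@H](CO)C(C)C)ccc1O` differs from compound 2 at that position: 1-(hydroxymethyl)-2-methylpropyl in place of 2-(methoxymethyl)-1-methylpropyl on a saturated chain carbon bound to two aromatic carbons. Among the compounds with values here, the one step on record at this place stayed within the scatter, and all three measured values sit within the scatter of one another, so the change is expected to move the number little, with the step of a 1.0-fold higher number from compound 2 to compound 4 (0.01 log units; within the scatter) expected to remain within the scatter. Compound 4 is therefore estimated at 60000 nM, in a range from 25000 nM to 150000 nM.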

Compound 4, half-maximal inhibitory concentration: > 100000 nM
Compound 4: only a limit was reported (the forecaster's own chance of this, stated with the estimate: 15%); middle value at least 1.6-fold (0.22 log units) away from the limit.
By their numbers in this assay, from the lowest: compounds 2, 3 and 1 (each within the scatter of the next). At a limit, above all of these: compound 4.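

In this assay compound 4 gives > 100000 nM, which is a limit and not a number. Read against compound 2, the swap to 1-(hydroxymethyl)-2-methylpropyl on a saturated chain carbon bound to two aromatic carbons is an at least 1.7-fold higher number from compound 2 to compound 4 (0.23 log units; that floor lies within the scatter), while hydrogen in place of methyl on an oxygen on a saturated carbon is an at least 1.4-fold higher number from compound 1 to compound 4 (0.16 log units; that floor lies within the scatter). Both floors lie within the scatter, so neither step establishes a real change, yet this position has now given the first result that cannot be placed on the scale: the limit of > 100000 nM in this assay, at which 1 of the 4 values shown sits.

As far as these compounds go, how far compound 4 lies past its limit remains open, so the true size of both steps is unknown. Also open, from the compounds shown here alone, is how an amine or a carboxylic acid in place of the hydroxyl of the 1-(hydroxymethyl)-2-methylpropyl group, or a longer chain, would read at this position.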